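Tolerance Holds at the Limit Across the Amine Series

The source may report more compounds than this note shows. Statements on the series, on what has been measured and on what is new or still open speak of the compounds shown alone.

Compound 1 `Cc1ccc2cc(CN(Cc3ccc(C(C)C)cc3)Cc3ccccc3F)c(=O)[nH]c2c1`: in a toxicity assay on MDCK cells (Canis lupus familiaris) for cytotoxicity, read by crystal violet staining, with a stated time of 48 h (a higher number here means that more compound is tolerated, a lower number that less compound is tolerated), the reading is a limit, > 33000 nM.
Compound 2 `CCc1ccc2[nH]c(=O)c(CN(Cc3ccc(C(C)(C)C)cc3)Cc3ccc(F)c(F)c3)cc2c1`: in this assay the reading is a limit, > 33000 nM.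
Compound 3 `Cc1ccc2cc(CN(Cc3ccc(F)cc3)C(=O)c3ccccc3)c(=O)[nH]c2c1`: in this assay the reading is a limit, > 33000 nM.

Compound 2 therefore sits where every measured compound sits, at the limit of > 33000 nM in this assay, at which 3 of the 3 values shown sit; none of the three gives a number. Compound 4 `CCc1ccc2[nH]c(=O)c(CN(Cc3ccc(C(C)(C)C)cc3)[C@@H](C)c3ccc(F)cc3)cc2c1` differs from compound 2 by 1-(4-fluorophenyl)ethyl in place of 3,4-difluorobenzyl on an amine nitrogen. For the measured compounds named here, no step between measured compounds is available to weigh this change, so the expectation rests on the shared limit. Compound 4 is expected to stay at or near that limit, with an estimated step that the limit leaves unreadable from compound 2 to compound 4, no more than the usual scatter. The estimate for compound 4 is 40000 nM, within 15000 nM to 100000 nM.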

Compound 4, half-maximal cytotoxic concentration: > 5000 nM
Compound 4 gave a limit, no number; the forecaster's own chance of this, stated with the estimate: 80%; the middle value is on the limit's open side.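

Compound 2 and compound 4 each gave only a limit, so the swap of 3,4-difluorobenzyl for 1-(4-fluorophenyl)ethyl cannot be read as a step. The compounds shown leave open what concentration of any of them proves cytotoxic in this assay.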